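The compounds below may be only part of what the source reports. "The series", "measured", "known", "first", "only" and "open" are said of these compounds alone.

Measured so far in a functional assay on MDA-MB-231 cells (Homo sapiens) for antiproliferative activity, read by MTT assay; on this read-out higher numbers stand for weaker inhibition and lower numbers for stronger inhibition:
compound 1 `CCCCCCCCCCCCCCCc1cc(=O)c2c(O)c(C)c(OCOC)c(C)c2o1` gives > 87000 nM, a limit of this assay rather than a number.
compound 2 `CCCCC/C=C\C/C=C\CCCCCCCc1cc(=O)c2c(O)c(C)c(OCOC)c(C)c2o1` gives 16100 nM.
compound 3 `CCCC/C=C\CCCCCCCCCc1cc(=O)c2c(O)c(C)c(OCOC)c(C)c2o1` gives > 87000 nM, likewise a limit.

Compound 1 thus stands at the limit where two of the three values sit (the limit of > 87000 nM in this assay, at which 2 of the 3 values shown sit). For the measured compounds named here, the one fully readable step is an at least 5.4-fold lower number from compound 1 to compound 2 (0.73 log units; beyond the scatter); the step that the two limits leave unreadable from compound 1 to compound 3, and an at least 5.4-fold higher number from compound 2 to compound 3 (0.73 log units; beyond the scatter). All three steps concern the chain on the core, none touches the ring positions.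

Compound 4 `CCCCCCCCCCCCCCCc1cc(=O)c2c(O)c(C)c(OCOC)cc2o1` differs from compound 1 by hydrogen in place of methyl on an aromatic carbon. Going by the values given here, no measured step bears on this change, so no direction can be read from the series, and with compound 1 at a limit only a large gain would become visible. The expectation is that compound 4 stays near the limit, estimated at 120000 nM (range 40000 nM to 400000 nM), which is expected to mean a step that the limit leaves unreadable from compound 1 to compound 4.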

Compound 4, half-maximal inhibitory concentration: > 87000 nM
Compound 4: only a limit was reported (the forecaster's own chance of this, stated with the estimate: 75%); the middle value does not contradict the limit.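

Compound 4 gives > 87000 nM, a limit and not a number; compound 1 also stands at a limit, so no step can be read between the two: the limit of > 87000 nM in this assay, at which 3 of the 4 values shown sit.

Whether hydrogen in place of methyl on this aromatic carbon changes the inhibition at all stays open in the compounds shown.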